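A Borrowed Group on a Different Core

The source may report more compounds than this note shows. Statements on the series, on what has been measured and on what is new or still open speak of the compounds shown alone.

Compound 1 `Cc1c(C(=O)NS(C)(=O)=O)c(-c2cccc(N3CCN(c4ccc(NS(=O)(=O)c5ccc(N[C@H](CCN(C)C)CSc6ccccc6)c([N+](=O)[O-])c5)cc4)CC3)c2)c(-c2ccc(Cl)cc2)n1C`: 0.9 nM
Compound 2 `CN(C)CC[C@H](CSc1ccccc1)Nc1ccc(S(=O)(=O)Nc2ccc(N3CCN(c4cccc(-c5cncn5-c5ccc(Cl)cc5)c4)CC3)cc2)cc1[N+](=O)[O-]`: 46 nM
Compound 3 `CN(C)CC[C@H](CSc1ccccc1)Nc1ccc(S(=O)(=O)Nc2ccc(N3CCN(c4cccc(-c5ccnn5-c5ccc(Cl)cc5)c4)CC3)cc2)cc1[N+](=O)[O-]`: 110 nM

All three were tested in an assay on isolated protein for binding affinity to Apoptosis regulator Bcl-2 (Homo sapiens), read by fluorescence polarization, with a stated time of 2 h; a higher number here means a weaker inhibitor, a lower number a stronger inhibitor. Compound 3 has the highest number of the three. Its nearest neighbour is compound 2, and the step of a 2.4-fold higher number from compound 2 to compound 3 (0.38 log units; beyond the scatter) came from swapping one five-membered ring core for another. Compound 1 lies far lower, but it differs from compound 3 both in its core and in carrying a (methylsulfonyl)carbamoyl group, so that gap cannot be pinned on either change alone. Compound 4 `CN(C)CC[C@H](CSc1ccccc1)Nc1ccc(S(=O)(=O)Nc2ccc(N3CCN(c4cccc(-c5c(C(=O)NS(C)(=O)=O)cnn5-c5ccc(Cl)cc5)c4)CC3)cc2)cc1[N+](=O)[O-]` carries that same group onto the core of compound 3: (methylsulfonyl)carbamoyl in place of hydrogen on an aromatic carbon. Among the measured compounds shown here, no measured step isolates this change, and the comparison with compound 1 is only a hint. Still, a clear drop is expected, with the step of an 11-fold lower number from compound 3 to compound 4 (1.04 log units; beyond the scatter). Compound 4 is therefore estimated at 10 nM, within 2 nM to 50 nM.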

Compound 4, half-maximal inhibitory concentration: 5.4 nM
Compound 4: the middle estimate sits 1.9-fold (0.27 log units) above what was measured; measured number inside the range.
By their numbers in this assay, from the lowest: compound 1; then compound 4; then compound 2; then compound 3.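

In this assay the (methylsulfonyl)carbamoyl group on this aromatic carbon gives a 20-fold lower number from compound 3 to compound 4 (1.31 log units; beyond the scatter) as a single change on the same core. This is the first step shown that isolates the group, whereas the gap to compound 1 mixed it with a change of core. No measurement here explains why the number falls. As far as these compounds go, whether a carboxylic acid or a plain carboxamide at this position would give a similar drop remains open. So does the size of the step that (methylsulfonyl)carbamoyl would give on the core of compound 2.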